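This account rests on a few compounds, and the source may have more. Where it says the series, first, only, none or still open, it means among the compounds named here.

Of the compounds shown here, three built on one shared core have been tested in a physicochemical assay for solubility; a lower number here means a less soluble compound, a higher number a more soluble compound. Compound 1 `CNC(=O)c1cc(C(=O)NC2CCC2)cn(Cc2cccc(NC)c2)c1=O` reaches only a limit of the assay, >= 155 ug/mL. Compound 3 `CNC(=O)c1cc(C(=O)NC2CCC2)cn(Cc2cccnc2)c1=O` likewise stops at a limit, >= 99 ug/mL. For the measured compounds named here, the one step measured between them, a step that the two limits leave unreadable from compound 1 to compound 3, cannot be sized because both of its ends sit at limits the limit of >= 155 ug/mL in this assay, at which 1 of the 3 values shown sits (the limit of >= 99 ug/mL in this assay, at which 1 of the 3 values shown sits). Compound 2 `CNC(=O)c1cc(C(=O)NCCCC2CNCCO2)cn(Cc2ccccc2)c1=O` also stands at a limit, >= 194 ug/mL. Going by the values given here, since every value shown is a limit (the limit of >= 194 ug/mL in this assay, at which 1 of the 3 values shown sits), no compound can be ranked against another, and compound 2 can only be said to sit at or beyond the top of what the assay reports.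

Compound 4 `CNC(=O)c1cc(C(=O)NCC(C)C)cn(Cc2ccccc2)c1=O` differs from compound 2 in a single place: isopropyl in place of 2-(morpholin-2-yl)ethyl on a saturated chain carbon bound to an amide-type nitrogen. Cut one bond further out, the same change reads isobutylamino in place of (3-(morpholin-2-yl)propyl)amino.

Among the compounds with values here, no measured step concerns this position, and the one step that exists, a step that the two limits leave unreadable from compound 1 to compound 3, is unreadable and lies elsewhere on the molecule. The expectation therefore rests on the structural change alone, and the estimated step of an at least 2.4-fold lower number from compound 2 to compound 4 (0.38 log units; beyond the scatter) is taken as a drop, held with wide uncertainty. Compound 4 is expected to give about 80 ug/mL in this assay, within a range from 20 ug/mL to 200 ug/mL.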

Compound 4, solubility: 43 ug/mL
Beside the measured number, compound 4's estimate is 1.9-fold (0.27 log units) above it; the range from low to high includes it.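

For the compounds shown here, until now, no step in this assay could be read, and none touched this position, on a saturated chain carbon bound to an amide-type nitrogen. Here, isopropyl in place of 2-(morpholin-2-yl)ethyl comes with an at least 4.5-fold lower number from compound 2 to compound 4 (0.65 log units; beyond the scatter), so a change at this place can give a step larger than the differences seen between repeated measurements. The step has only a lower bound, since compound 2 stands at a limit of the assay rather than at a number: the limit of >= 194 ug/mL in this assay, at which 1 of the 4 values shown sits.

The change takes away a six-membered non-aromatic ring with its nitrogen and oxygen and also alters the chain, so the compounds shown cannot divide the step among these features; a 3-aminopropyl group, which has a chain and an amine but no ring, or a plain longer alkyl chain such as n-hexyl, would help to separate them. On these data alone, it also remains open whether the same exchange gives a step of similar size when the benzyl group of compound 2 is replaced by the pyridin-3-yl or 3-(methylamino)phenyl groups found in the other compounds.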